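The source may report more compounds than this note shows. Statements on the series, on what has been measured and on what is new or still open speak of the compounds shown alone.

Measured so far in an assay on membranes from HeLa cells for displacement of a labelled ligand from adenosine receptor A3 (Homo sapiens), read by scintillation counting, with a stated time of 180 min, tested at 1 uM; a lower number here means less inhibition, a higher number more inhibition at the concentration tested (going by the name of the read-out):
- compound 1 `COC(=O)C1=C(C)N(C)C(=O)NC1c1cccs1`: 15%
- compound 2 `CCOC(=O)C1=C(C)N(C)C(=O)NC1c1cccs1`: 2%
- compound 3 `CCNC(=O)C1=C(C)NC(=O)NC1c1ccco1`: 3%

Among the compounds with values here, the one single-point step measured is a number 13 percentage points lower from compound 1 to compound 2 (beyond the scatter); the change is methyl in place of hydrogen on a saturated chain carbon bound to an oxygen next to a carbonyl group. Compound 2 and compound 3 give numbers within the scatter of each other, so nothing separates them. Compound 3 and compound 1 are built on different cores; the difference between the two cores is not broken down here.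

Compound 4 `CC1=C(C(=O)NC(C)C)C(c2ccco2)NC(=O)N1` is not yet measured in this assay. It differs from compound 3 by methyl in place of hydrogen on a saturated chain carbon bound to an amide-type nitrogen and a saturated chain carbon. Within the data shown here, this is the same kind of change as the one from compound 1 to compound 2, but not the same: there the added carbon sits on a saturated chain carbon bound to an oxygen next to a carbonyl group, here on a saturated chain carbon bound to an amide-type nitrogen and a saturated chain carbon, and the two cores also differ.

Beside the measured step, the expected step for compound 4 is no change at the digits printed from compound 3 to compound 4 (within the scatter); this rests on compound 3 already giving 3% in this assay, which leaves little room for a further lowering, and on the measured step pointing down rather than up. The estimate for compound 4 in this assay is 3%, expected to fall between -5% and 12%.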

Compound 4, a percentage reported as inhibition, at one concentration (the size of the read-out at that concentration, not a potency): 4%
Estimate against measurement, compound 4: 1 percentage points below; low and high end bracket the measured number.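

In this assay, changing ethylcarbamoyl to isopropylcarbamoyl gives a number 1 percentage points higher from compound 3 to compound 4 (within the scatter), so this methyl in place of hydrogen does not separate the two compounds. Within the data shown here, this does not establish a rule for carrying the change between cores: there are only two pairs, the methyl sits on a different chain in each, and the pair on the core of compound 3 starts close to the bottom of the read-out at a single tested concentration, leaving little room to show a lowering. Set side by side, the two steps cannot be told apart, although only the step on the core of compound 1 is beyond the scatter: the same change on two cores in this assay, a number 13 percentage points lower (beyond the scatter) from compound 1 to compound 2 and a number 1 percentage points higher (within the scatter) from compound 3 to compound 4, 14 percentage points apart, within the scatter of two such steps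

The compounds shown leave open how the core of compound 3 responds to other groups on the amide nitrogen, such as a longer chain, a terminal amine or a carboxylic acid. Going by these compounds, it also remains open whether the same methyl change would read alike on a compound of this core with a higher starting number.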